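This account rests on a few compounds, and the source may have more. Where it says the series, first, only, none or still open, it means among the compounds named here.

In an ADME assay on MT4 cells (Homo sapiens) for cytotoxicity, read by MTT assay, with a stated time of 5 days (a higher number here means that more compound is tolerated, a lower number that less compound is tolerated), compound 1 (`Cc1cc(/C=C/C#N)cc(C)c1Oc1cc(Cl)nc(Nc2ccc(C#N)cc2)n1`) gives 4310 nM, the lowest of three numbers and beyond the scatter from the other two. Compound 2 (`C=CCNc1cc(Oc2c(C)cc(/C=C/C#N)cc2C)cc(Nc2ccc(C#N)cc2)n1`) gives 82100 nM and compound 3 (`Cc1cc(/C=C/C#N)cc(C)c1Oc1cc(NCC2CCCO2)nc(Nc2ccc(C#N)cc2)c1`) gives 73600 nM. Compound 4 (`Cc1cc(/C=C/C#N)cc(C)c1Oc1cc(NCCC#N)nc(Nc2ccc(C#N)cc2)n1`) carries (2-cyanoethyl)amino in place of chloro on an aromatic carbon. Going by the values given here, no measured step covers this change directly. The nearest evidence is a 1.1-fold lower number from compound 2 to compound 3 (0.05 log units; within the scatter), an exchange within an amino side chain, so the side chain's identity is expected to matter little. Both of those compounds have an amino side chain, but their core differs from that of compound 1, so the comparison is loose. An upward move in this assay is expected, with an estimated 7.0-fold higher number from compound 1 to compound 4 (0.84 log units; beyond the scatter). The estimate for compound 4 is 30000 nM, with an expected range of 8000 nM to 100000 nM.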

Compound 4, half-maximal cytotoxic concentration: 1000 nM
Beside the measured number, compound 4's estimate is 30-fold (1.48 log units) above it; measured number below the stated range.
By their numbers in this assay, from the lowest: compound 4; then compound 1; then compounds 3 and 2 (each within the scatter of the next).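

In this assay, putting (2-cyanoethyl)amino in place of chloro on this aromatic carbon gives a 4.3-fold lower number from compound 1 to compound 4 (0.63 log units; beyond the scatter), so less compound is tolerated with the new group there. This is the first step shown at this position, and unlike the one earlier step, it lies beyond the scatter. No measurement shown accounts for the change. Still open, as far as these compounds go, is whether the lower number goes with the amino nitrogen or with the nitrile at the chain end. A plain ethylamino group or a longer cyanoalkylamino chain on this carbon of the core of compound 1 would separate the two.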